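The source may report more compounds than this note shows. Statements on the series, on what has been measured and on what is new or still open speak of the compounds shown alone.

Measured in an ADME assay on CCRF-CEM cells (Homo sapiens) for cytotoxicity, read by cell counting; a lower number here means that less compound is tolerated, a higher number that more compound is tolerated:
Compound 1 `Cc1cc(C)cc(S(=O)(=O)c2c(C(=O)NCN3CCCC3)[nH]c3ccc(Br)cc23)c1`: 9600 nM
Compound 2 `Cc1cc(C)cc(S(=O)(=O)c2c(C(=O)NCN3CCCCC3)[nH]c3ccc([N+](=O)[O-])cc23)c1`: 12000 nM

Only these two values exist so far. The gap between them lies within the scatter, so compound 2, at 12000 nM, cannot be ranked against compound 1.

Compound 3 `Cc1cc(C)cc(S(=O)(=O)c2c(C(=O)NCN3CCCCC3)[nH]c3ccc(Br)cc23)c1` has not yet been measured. It is compound 2 with bromo in place of nitro on an aromatic carbon. That carbon belongs to a six-membered aromatic ring of carbon only, part of a fused or bridged system of two rings.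

Among the measured compounds shown here, no measured step shows this change directly, so any expectation in this assay rests on a thin basis. Compound 1 reads 9600 nM and compound 2 reads 12000 nM, and that narrow spread gives no reason to expect a large move in either direction. The expected 1.2-fold lower number from compound 2 to compound 3 (0.08 log units; within the scatter) is therefore one that stays within the scatter. For compound 3 the estimated value is 10000 nM, with an expected range of 5000 nM to 20000 nM.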

Compound 3, half-maximal cytotoxic concentration: 10000 nM
Compound 3: middle estimate and measured number agree at the digits printed, within the range that was stated.
By their numbers in this assay, from the lowest: compounds 1, 3 and 2 (each within the scatter of the next).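

In this assay, among the compounds shown here, compound 3 joins compounds 1 and 2, which differ from each other in two places, and so gives the first reading of each place on its own. Bromo in place of nitro gives a 1.2-fold lower number from compound 2 to compound 3 (0.08 log units; within the scatter) on the aromatic carbon, and piperidin-1-yl in place of pyrrolidin-1-yl gives a 1.0-fold higher number from compound 1 to compound 3 (0.02 log units; within the scatter) on the saturated chain carbon bound to an amide-type nitrogen, so neither exchange stands clear of the scatter. Nothing available here accounts for these readings, and the finding holds only for these two pairs.

On these data alone, each place is still known from a single exchange, so it remains open whether an amine or a carboxylic acid on the aromatic carbon, or a morpholin-4-yl group on the chain carbon, would also stay within the scatter. As far as these compounds go, it is also open whether the two places act independently, a question that a compound joining pyrrolidin-1-yl with nitro on the shared core would address.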